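The source may report more compounds than this note shows. Statements on the series, on what has been measured and on what is new or still open speak of the compounds shown alone.

Measured compounds:
compound 1, `CN(C)CCN(C)c1ccc(C#CC(C)(O)c2nccs2)cc1Nc1ncnc2[nH]ccc12` — 484 nM
compound 2, `CC(O)(C#Cc1ccc(N2CCNCC2)c(Nc2ncnc3[nH]ccc23)c1)c1nccs1` — 47.9 nM
compound 3, `CC(O)(C#Cc1ccc(OC2CCOCC2)c(Nc2ncnc3[nH]ccc23)c1)c1nccs1` — 112 nM

All three share one core and differ only in the group on the aromatic carbon ortho to the large group. In an assay for inhibition of mitogen-activated protein kinase kinase kinase 14 (Homo sapiens), read by luminescence and ADP-Glo, with a stated time of 120 min, in the presence of a further agent that is not named here (a higher number here means a weaker inhibitor, a lower number a stronger inhibitor), compound 3 stands second highest of the three numbers: nearest to it is compound 2, farthest is compound 1. The relevant steps are a 10-fold lower number from compound 1 to compound 2 (1.00 log units; beyond the scatter), a 4.3-fold lower number from compound 1 to compound 3 (0.64 log units; beyond the scatter) and a 2.3-fold higher number from compound 2 to compound 3 (0.37 log units; beyond the scatter), all modest but beyond the scatter.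

Compound 4, `CC(O)(C#Cc1ccc(N2CCN(S(=O)(=O)C3CC3)CC2)c(Nc2ncnc3[nH]ccc23)c1)c1nccs1`, has not yet been measured. It differs from compound 3 by 4-(cyclopropylsulfonyl)piperazin-1-yl in place of (oxan-4-yl)oxy on an aromatic carbon. Within the data shown here, the change re-enters the piperazin-1-yl ring of compound 2 but carries a cyclopropylsulfonyl group on its second nitrogen, so no measured pair matches it exactly. Among the measured compounds shown here, the only step bearing directly on it is the reverse of a 2.3-fold higher number from compound 2 to compound 3 (0.37 log units; beyond the scatter), which points to a modestly lower number; the step of a 10-fold lower number from compound 1 to compound 2 (1.00 log units; beyond the scatter) shows the ring with a free second nitrogen is the better of the two amines measured, and the sulfonyl group here is new to the series, so the expectation is held loosely.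

Compound 4 is therefore expected to give 70 nM in this assay, with a range of 20 nM to 250 nM, a step of a 1.6-fold lower number from compound 3 to compound 4 (0.20 log units; within the scatter) in expectation.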

Compound 4, half-maximal inhibitory concentration: 16.2 nM
Estimate against measurement, compound 4: 4.3-fold (0.64 log units) above; measured number below the stated range.
By their numbers in this assay, from the lowest: compound 4; then compound 2; then compound 3; then compound 1.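

In this assay, a 3.0-fold lower number from compound 2 to compound 4 (0.47 log units; beyond the scatter), so a hydrogen on the second nitrogen of the piperazin-1-yl ring is not needed for a low number, and a cyclopropylsulfonyl group on that nitrogen gives the lowest number in the series. Among these compounds, this aromatic carbon also accepts a much larger group than the earlier compounds showed: with 4-(cyclopropylsulfonyl)piperazin-1-yl, of 12 heavy atoms, in place of (oxan-4-yl)oxy, of 7, there is a 6.9-fold lower number from compound 3 to compound 4 (0.84 log units; beyond the scatter), and the same group in place of the open-chain amine gives a 30-fold lower number from compound 1 to compound 4 (1.48 log units; beyond the scatter), the only large step in the set. Nothing measured here accounts for the lower number of compound 4.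

The compounds shown leave open whether the effect in this assay follows the sulfonyl link, the cyclopropyl ring or simply any substituent on that nitrogen; a methylsulfonyl, an acetyl or a plain methyl group there would separate these. Also open, from the compounds shown here alone, is whether the step holds when the 3-hydroxy-3-(1,3-thiazol-2-yl)but-1-yn-1-yl group is replaced, for example by a shorter chain without the thiazole, since all four compounds carry that group unchanged.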